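Fluoro to Methoxy: Expected Binding of Compound 3

The source may report more compounds than this note shows. Statements on the series, on what has been measured and on what is new or still open speak of the compounds shown alone.

Compound 1 `CCc1ccc(NC(=O)CN2CCN(c3ccc(F)cc3)CC2)cc1` gives 6500 nM in an assay for displacement of a labelled ligand from DNA repair protein REV1 (Homo sapiens), read by fluorescence polarization, with a stated time of 1 h (on this read-out higher numbers stand for weaker binding and lower numbers for tighter binding), the lower of the two numbers recorded so far. Compound 2 `N#Cc1ccc(NC(=O)CN2CCN(c3ccc(F)cc3)CC2)cc1` gives 109000 nM in this assay, and the step of a 17-fold higher number from compound 1 to compound 2 (1.22 log units; beyond the scatter) was large. Compound 3 `CCc1ccc(NC(=O)CN2CCN(c3ccc(OC)cc3)CC2)cc1` differs from compound 1 by methoxy in place of fluoro on an aromatic carbon. Going by the values given here, no measured step touches this change, so the large step to compound 2 offers no guide, and nothing points to a step beyond the scatter in this assay. Compound 3 is therefore expected to give about 8000 nM (range 2500 nM to 25000 nM), an expected step of a 1.2-fold higher number from compound 1 to compound 3 (0.09 log units; within the scatter) within the usual scatter.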

Compound 3, dissociation constant: 3600 nM
Estimate against measurement, compound 3: 2.2-fold (0.35 log units) above, and the stated range covers the measured number.
By their numbers in this assay, from the lowest: compounds 3 and 1 (each within the scatter of the next); then compound 2.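

Going by these compounds alone, replacing fluoro with methoxy on the 4-substituted phenyl gives a 1.8-fold lower number from compound 1 to compound 3 (0.26 log units; within the scatter) in this assay, so the first measured change at this position leaves the read-out within the scatter. This position therefore accepts the swap from 4-fluorophenyl to 4-methoxyphenyl without a measurable change in binding. No available evidence bears on why this is so.

Going by these compounds, whether this tolerance extends to a longer chain such as butoxy, an amine or a carboxylic acid at this position remains open. So does whether methoxy behaves the same way with the nitrile of compound 2 in place of the ethyl group.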